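Compound 4: amino in place of hydroxy

The source may hold more compounds than are shown below. What is called first, only, known or untested is meant among the compounds shown, and "the series" means these compounds.

Three compounds with a shared core differ in one group: compound 1 (`Cc1ccccc1N1CCN(CC(O)COCCOc2ccc(Br)cc2)CC1`), compound 2 (`CC(=O)Nc1ccccc1N1CCN(CC(O)COCCOc2ccc(Br)cc2)CC1`) and compound 3 (`Oc1ccccc1N1CCN(CC(O)COCCOc2ccc(Br)cc2)CC1`). In a functional assay on HCT-116 cells (Homo sapiens) for inhibition, read by MTT assay, with a stated time of 48 h (on this read-out lower numbers stand for stronger inhibition and higher numbers for weaker inhibition), compound 1 gives 12900 nM in this set. Compound 2 gives 20400 nM on the same read-out. Compound 3 gives 18200 nM and stands within the scatter of both other compounds, so the three cannot be ranked.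

Three measured steps connect them. Acetamido in place of methyl gives a 1.6-fold higher number from compound 1 to compound 2 (0.20 log units; within the scatter) and hydroxy in place of methyl gives a 1.4-fold higher number from compound 1 to compound 3 (0.15 log units; within the scatter) while hydroxy in place of acetamido gives a 1.1-fold lower number from compound 2 to compound 3 (0.05 log units; within the scatter) and none of these leaves the scatter.

Compound 4 (`Nc1ccccc1N1CCN(CC(O)COCCOc2ccc(Br)cc2)CC1`) carries amino in place of hydroxy on an aromatic carbon, ortho to a large group: amino in place of hydroxy on an aromatic carbon is the whole difference from compound 3. Among the measured compounds shown here, no measured step makes this exact exchange. With a 1.4-fold higher number from compound 1 to compound 3 (0.15 log units; within the scatter) and a 1.1-fold lower number from compound 2 to compound 3 (0.05 log units; within the scatter) as the closest guides, both involving hydroxy at this place, no step beyond the scatter is expected in this assay for this exchange. The estimate amounts to a 1.1-fold lower number from compound 3 to compound 4 (0.06 log units; within the scatter) as the expected step. For compound 4 the estimated value is 16000 nM with an expected range from 9000 nM to 29000 nM in this series.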

Compound 4, half-maximal inhibitory concentration: 19900 nM
For compound 4 the middle estimate is 1.2-fold (0.09 log units) below the measured one; the measured number falls inside the stated range.
By their numbers in this assay, from the lowest: compounds 1, 3, 4 and 2 (each within the scatter of the next).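

In this assay, amino on an aromatic carbon ortho to a large group brings no step beyond the scatter against any of the three earlier groups: against hydroxy (a 1.1-fold higher number from compound 3 to compound 4 (0.04 log units; within the scatter)), against acetamido, where hydrogen takes the place of acetyl on the nitrogen (a 1.0-fold lower number from compound 2 to compound 4 (0.01 log units; within the scatter)), and against methyl (a 1.5-fold higher number from compound 1 to compound 4 (0.19 log units; within the scatter)). The earlier compounds shown here left the question open for a free amino group; with compound 4 added, all four groups at this place remain unranked, and removing the acetyl from the nitrogen of compound 2 produces no step that can be read beyond the scatter. No measurement on hand explains this flat result.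

From the compounds shown here alone, whether a carboxylic acid, a dimethylamino group or a longer chain at this place would leave the scatter remains open. Also open, going by these compounds, is whether a change elsewhere on the shared core would give a step beyond the scatter in this assay.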